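The source may report more compounds than this note shows. Statements on the series, on what has been measured and on what is new or still open speak of the compounds shown alone.

Measured so far: compound 1 `OC1CCN(c2ccc(-c3ccccc3Cl)nn2)CC1` gives 38 mg/kg in a functional assay on the whole organism with Mus musculus as the target; a higher number here means that more compound is needed for the effect, a lower number that less compound is needed; compound 2 `OC1CCN(c2ccc(-c3ccc(Cl)cc3Cl)nn2)CC1` gives 8.5 mg/kg.

Compound 1 thus stands with the higher of the two numbers. Compound 3 `OC1CCN(c2ccc(-c3cc(Cl)ccc3Cl)nn2)CC1` differs from compound 1 by chloro in place of hydrogen on an aromatic carbon. Going by the values given here, the one measured step that bears on this change is a 4.5-fold lower number from compound 1 to compound 2 (0.65 log units; beyond the scatter), which also put chloro in place of hydrogen on an aromatic carbon of the same ring, though in compound 3 the chloro enters meta to a large group and para to a chloro group. A step in the same direction, probably somewhat smaller, is therefore expected, a 2.5-fold lower number from compound 1 to compound 3 (0.40 log units; beyond the scatter). Compound 3 is estimated at 15 mg/kg, within 6 mg/kg to 38 mg/kg.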

Compound 3, dose for half-maximal effect: 131 mg/kg
For compound 3 the middle estimate is 8.7-fold (0.94 log units) below the measured one, outside the stated range (above it).
By their numbers in this assay, from the lowest: compound 2; then compound 1; then compound 3.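

In this assay, chloro in place of hydrogen on this ring does not act in one direction. Meta to a large group and para to a chloro group, the exchange gives a 3.4-fold higher number from compound 1 to compound 3 (0.54 log units; beyond the scatter), whereas the chloro entering compound 2 gave a 4.5-fold lower number from compound 1 to compound 2 (0.65 log units; beyond the scatter), so the sign of the step depends on where chloro enters. Nothing measured here accounts for this reversal.

Going by these compounds, whether fluoro, methyl or methoxy at this same carbon would also raise the number remains open. So does whether the hydroxyl group on the other ring of the core influences the size of this step.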